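The source may hold more compounds than are shown below. What is called first, only, known or untested is meant among the compounds shown, and "the series" means these compounds.

Of the compounds shown here, three sharing one core have been measured in an ADME assay on microsomes from liver (Mus musculus) for metabolic stability, read by LC-MS, with a stated time of 30 min, tested at 0.1 uM; on this read-out lower numbers stand for a less stable compound and higher numbers for a more stable compound. In this assay, compound 1 `FC(F)(F)c1cccc(-c2nc3cnc(Nc4ccccn4)cc3[nH]2)c1`, with a pyridin-2-yl group, gives 47%. Compound 2 `COc1ccnc(Nc2cc3[nH]c(-c4cccc(C(F)(F)F)c4)nc3cn2)c1`, with a 4-methoxypyridin-2-yl group, gives 62%. Compound 3 `FC(F)(F)c1cccc(-c2nc3cnc(Nc4cnccn4)cc3[nH]2)c1`, with a pyrazin-2-yl group, gives 7%, the lowest of the three numbers and clearly apart from the other two.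

Compound 4 `FC(F)(F)c1ccc(Nc2cc3[nH]c(-c4cccc(C(F)(F)F)c4)nc3cn2)nc1` has not yet been measured. It has 5-(trifluoromethyl)pyridin-2-yl in place of pyrazin-2-yl on a nitrogen on an aromatic ring.

For the measured compounds named here, three measured steps bear on this change. Putting pyrazin-2-yl in place of pyridin-2-yl gave a number 40 percentage points lower from compound 1 to compound 3 (beyond the scatter), a large step. Putting pyrazin-2-yl in place of 4-methoxypyridin-2-yl gave a number 55 percentage points lower from compound 2 to compound 3 (beyond the scatter), also large. Adding methoxy to the pyridin-2-yl group gave a number 15 percentage points higher from compound 1 to compound 2 (beyond the scatter), a modest step, so a substituent on this group can shift the number. Going by the values given here, no measured compound carries the trifluoromethyl group on this group, which leaves its contribution open. Leaving pyrazin-2-yl for a substituted pyridin-2-yl group reverses the direction of the step to compound 3 seen in both large cases, so a large rise is expected, and the estimated step is a number 41 percentage points higher from compound 3 to compound 4 (beyond the scatter). Compound 4 is therefore expected to give about 48%, with an estimated range from 25% to 72%.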

Compound 4, percent of the compound remaining: 91%
Estimate against measurement, compound 4: 43 percentage points below; measured number outside the range, above it.
By their numbers in this assay, from the lowest: compound 3; then compound 1; then compound 2; then compound 4.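

In this assay, for the compounds shown here, this position proves able to carry a much larger swing than the earlier compounds showed: exchanging pyrazin-2-yl for 5-(trifluoromethyl)pyridin-2-yl gives a number 84 percentage points higher from compound 3 to compound 4 (beyond the scatter), and compound 4 has the highest number of the four. Adding trifluoromethyl to the pyridin-2-yl group gives a number 44 percentage points higher from compound 1 to compound 4 (beyond the scatter), so a substituent on the pyridin-2-yl group can shift this read-out by far more than the modest methoxy step suggested. Exchanging 4-methoxypyridin-2-yl for 5-(trifluoromethyl)pyridin-2-yl still gives a number 29 percentage points higher from compound 2 to compound 4 (beyond the scatter), which shows that the two substituted groups do not land at the same level, although both lie above the unsubstituted pyridin-2-yl group of compound 1.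

Nothing shown here gives a reason for these differences, so the cause of the rise remains unknown. On these data alone, it also remains open whether the rise belongs to trifluoromethyl in particular or would also come with a chlorine atom, a nitrile or an amine on the same ring, and whether trifluoromethyl would lift the pyrazin-2-yl group as well.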